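This account rests on a few compounds, and the source may have more. Where it says the series, first, only, none or still open, it means among the compounds named here.

For the measured compounds named here, in an ADME assay on HUVEC cells (Homo sapiens) for cytotoxicity, read by MTT assay, with a stated time of 72 h (a lower number here means a stronger inhibitor, a higher number a weaker inhibitor), compound 3 `CC(CC[C@H]1/C(=C/c2ccc([N+](=O)[O-])cc2)CC[C@H]2C(C)(C)CCC[C@]12C)CC(=O)O` gives 194000 nM, the only actual number among the three measured compounds. Compound 1 `COc1ccc(/C=C2\CC[C@H]3C(C)(C)CCC[C@]3(C)[C@H]2CCC(C)CC(=O)O)cc1` stops at a limit of the assay, > 200000 nM. Compound 2 `Cc1ccc(/C=C2\CC[C@H]3C(C)(C)CCC[C@]3(C)[C@H]2CCC(C)CC(=O)O)cc1` likewise sits at a limit, > 200000 nM. Two of the three values therefore rest at the same limit (the limit of > 200000 nM in this assay, at which 2 of the 3 values shown sit). The change from compound 1 to compound 2 is a step that the two limits leave unreadable a step that the two limits leave unreadable from compound 1 to compound 2. Putting nitro in place of methoxy gives an at least 1.0-fold lower number from compound 1 to compound 3 (0.01 log units; that floor lies within the scatter), and putting nitro in place of methyl gives an at least 1.0-fold lower number from compound 2 to compound 3 (0.01 log units; that floor lies within the scatter); both floors lie within the scatter, so no readable difference separates the three compounds.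

Compound 4 `COc1ccc(/C=C2\CC[C@H]3C(C)(C)CCC[C@]3(C)[C@H]2CCC(C)CC(=O)O)cc1OC` differs from compound 3 by 3,4-dimethoxyphenyl in place of 4-nitrophenyl on a double-bonded chain carbon bound to a double-bonded ring carbon. The aryl substituents examined so far, methoxy, methyl and nitro, all leave the number at or just beside the top of the assay, and none of the readable floors exceeds the scatter. Going by the values given here, a second methoxy on an aromatic carbon has no precedent in the measured compounds. The expected step of a 1.0-fold higher number from compound 3 to compound 4 (0.01 log units; within the scatter) in this assay is therefore none beyond the scatter, with a good chance that only a limit is returned rather than a number. Compound 4 is estimated at 200000 nM, within 110000 nM to 400000 nM.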

Compound 4, half-maximal inhibitory concentration: > 200000 nM
Compound 4 ended at the assay's limit; the forecaster's own chance of this, stated with the estimate: 70%; the middle value lies on the limit itself.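

In this assay compound 4 gives > 200000 nM, a limit of the assay and not a number. Placing 3,4-dimethoxyphenyl in place of 4-nitrophenyl on a double-bonded chain carbon bound to a double-bonded ring carbon gives an at least 1.0-fold higher number from compound 3 to compound 4 (0.01 log units; that floor lies within the scatter), so even this exchange of a nitro-bearing ring for one carrying two methoxy groups opens no readable difference. The steps to compound 4 from compound 1 and from compound 2 cannot be read, and the added methoxy on an aromatic carbon extends the run of limit values to a ring with two substituents: the limit of > 200000 nM in this assay, at which 3 of the 4 values shown sit.

As far as these compounds go, it remains open whether any aryl group at this place gives a number clearly separated from the limit, for instance an amine or a hydroxyl on an aromatic carbon, and the limits conceal how compound 1, compound 2 and compound 4 compare with one another. Also open, from the compounds shown here alone, is whether a change away from the aryl group, such as an amide in place of the carboxylic acid, would move the number in this assay at all.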